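A Methoxy Group Takes the Place of Bromo

The source may report more compounds than this note shows. Statements on the series, on what has been measured and on what is new or still open speak of the compounds shown alone.

In a functional assay on MCF-A cells (Homo sapiens) for cytotoxicity (on this read-out higher numbers stand for weaker inhibition of growth and lower numbers for stronger inhibition of growth), compound 1 `COc1ccc(C2=C(c3ccc(SC)cc3)CC3CCCN3C2=O)cc1O` gives 5000 nM, and compound 2 `COc1ccc(C2=C(c3ccc(SC)cc3)CC3CCCN3C2=O)cc1Br` gives 6000 nM, so compound 2 stands within the scatter of compound 1. Compound 3 `COc1ccc(C2=C(c3ccc(SC)cc3)CC3CCCN3C2=O)cc1OC` differs from compound 2 by methoxy in place of bromo on an aromatic carbon, with methoxy in place of bromo, ortho to a methoxy group. Among the compounds with values here, the one measured step at this place, bromo in place of hydroxy, is a 1.2-fold higher number from compound 1 to compound 2 (0.08 log units; within the scatter) and lies within the scatter. No step beyond the scatter is therefore expected in this assay. The estimated change is a 1.2-fold lower number from compound 2 to compound 3 (0.08 log units; within the scatter). For compound 3 the expected value is 5000 nM, with an estimated range of 2000 nM to 12000 nM.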

Compound 3, concentration for 50% growth inhibition: 600 nM
The estimate for compound 3 lay 8.3-fold (0.92 log units) above the measured number; the whole stated range lies above it.
By their numbers in this assay, from the lowest: compound 3; then compounds 1 and 2 (each within the scatter of the next).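

In this assay this position turns out to respond to the group it carries: methoxy in place of bromo brings a 10-fold lower number from compound 2 to compound 3 (1.00 log units; beyond the scatter) in this series, and methyl in place of hydrogen on the oxygen brings an 8.3-fold lower number from compound 1 to compound 3 (0.92 log units; beyond the scatter) at the same place. Of the three groups, ortho to a methoxy group, only methoxy stands apart, as hydroxy and bromo lie within the scatter of each other. No evidence on hand explains this difference. The compounds shown leave open whether ethoxy, a longer chain on the oxygen, or an amine at this place would give a similar number.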